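The source may report more compounds than this note shows. Statements on the series, on what has been measured and on what is new or still open speak of the compounds shown alone.

Measured compounds:
Compound 1, `CCCCCCCCCCCCCCCCc1c(C)c(N(C)C)nc(C)c1O`, gives 11%.
Compound 2, `CCCCCCCCCCCCCCCCc1nc(N2CCC2)c(C)c(C)c1O`, gives 13%.
Compound 3, `Cc1c(N(C)C)nc(CCCCCCCCCCO)c(O)c1C`, gives 20%.

All three compounds were tested in a functional assay on cells (Lymphocyte, Homo sapiens), read by trypan blue exclusion, with a stated time of 16 h, tested at 0.1 uM; on this read-out higher numbers stand for a stronger effect at the one concentration tested and lower numbers for a weaker effect. Compound 3 has the number that sits at the top of the three as written, but the numbers for compound 2 and compound 1 both lie within the usual scatter of it, so the three readings cannot be told apart with any confidence. All of them are low, meaning a weak effect at the single concentration tested.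

Compound 4, `CCCCCCCCCCc1nc(N(C)C)c(C)c(C)c1O`, has not been measured in this assay. It differs from compound 3 in one place: hydrogen in place of hydroxy on a saturated chain carbon, ten or more bonds along the chain from an aromatic carbon. The change sits at the far end of a long saturated chain, well away from the ring, and the three measured compounds, which differ among themselves in several places, all give weak readings within the scatter of one another. Among the measured compounds shown here, no step between measured compounds is available to say what this particular change does. The expectation is therefore no step beyond the scatter, with the estimated change from compound 3 to compound 4 being a number 5 percentage points lower from compound 3 to compound 4 (within the scatter). Compound 4 is expected to give 15% in this assay, within a range from 5% to 30%.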

Compound 4, a percentage reported as activity, at one concentration (the size of the read-out at that concentration, not a potency): 6%
Beside the measured number, compound 4's estimate is 9 percentage points above it; the range from low to high includes it.
By their numbers in this assay, from the lowest: compounds 4, 1, 2 and 3 (each within the scatter of the next, the first and the last beyond it).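

In this assay, among the compounds shown here, the change at the far end of the chain gives the only step in this set that can be read in one place, a number 14 percentage points lower from compound 3 to compound 4 (beyond the scatter) and so the first direct view of what this position does. It shows that hydrogen in place of hydroxy on a saturated chain carbon, ten or more bonds along the chain from an aromatic carbon, is not a silent change: the end of the chain counts in this read-out, however far it lies from the aromatic carbon. Nothing shown explains why the number falls, and this single pair of low readings at one concentration gives no reason for it.

From the compounds shown here alone, it stays open whether the hydroxy itself matters or whether another group at the same chain end, such as an amine, a carboxylic acid or a methoxy group, would hold the reading at the level of compound 3. Going by these compounds, it is equally open whether a hydroxy on a longer chain would behave the same way, since the long-chain compound 1 and compound 2 differ from these two in more than one place.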